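The source may hold more compounds than are shown below. What is called first, only, known or untested is meant among the compounds shown, and "the series" means these compounds.

Working notes on the series. Compound 1 `COC(=O)CCNC(=O)[C@@H]1O[P@](=O)(OCOC(=O)c2scnc2C)OCC1(C)C` is measured in an ADME assay on blood (Homo sapiens) for pharmacokinetics; a lower number here means that the compound disappears faster, a higher number that the compound lasts longer. In this assay compound 1 gives < 0.16 h, which is a limit of the assay and not a number. Compound 2 `CC(C)(C)C(=O)OCO[P@@]1(=O)OCC(C)(C)[C@H](C(=O)NCCC(=O)O)O1` gives > 1 h in this assay, again a limit rather than a number. Compound 3 `COC(=O)CCNC(=O)[C@@H]1O[P@@](=O)(OCOC(=O)c2cc(C(C)(C)C)n[nH]2)OCC1(C)C` likewise returns a limit in this assay, namely > 1 h. Among the measured compounds shown here, compound 1 therefore stands at the limit of < 0.16 h in this assay, at which 1 of the 3 values shown sits, whereas the other two values stand at the limit of > 1 h in this assay, at which 2 of the 3 values shown sit; no step between measured compounds that differ in one place is available, so no measured difference can be sized.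

Compound 4 `COC(=O)CCNC(=O)[C@@H]1O[P@](=O)(OCOC(=O)c2ccnn2C)OCC1(C)C` carries the change (1-methyl-1H-pyrazol-5-yl in place of 4-methyl-1,3-thiazol-5-yl on a carbonyl carbon). For the measured compounds named here, no measured step shows what this exchange does in this assay; from the position of compound 1 alone, an upward step is expected, and the estimated step of an at least 3.1-fold higher number from compound 1 to compound 4 (0.49 log units; beyond the scatter) would likely lie beyond the scatter. For compound 4 the expected value in this assay is 0.5 h, within a range from 0.15 h to 2 h, with a real chance that only a limit is reported.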

Compound 4, half-life: < 0.16 h
Compound 4 ended at the assay's limit (the forecaster's own chance of this, stated with the estimate: 40%); middle value at least 3.1-fold (0.49 log units) away from the limit.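

In this assay, among the compounds shown here, compound 1 and compound 4 both end at a limit of the assay and not at a number, so no step between them can be read. The compounds shown leave open whether 1-methyl-1H-pyrazol-5-yl in place of 4-methyl-1,3-thiazol-5-yl on a carbonyl carbon changes the half-life at all.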